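The source may report more compounds than this note shows. Statements on the series, on what has been measured and on what is new or still open speak of the compounds shown alone.

Measured compounds, with their results in a functional assay on the whole organism (strain Swiss) with Mus musculus as the target, in the maximal electroshock model, with a stated time of 2 h, at a dose of 300 mg/kg by the intraperitoneal route; on this read-out lower numbers stand for a weaker effect and higher numbers for a stronger effect at the one dose given:

Compound 1 `CC(C(=O)N1CCN(c2ccccc2C(F)(F)F)CC1)N1C(=O)CCC1=O` gives 75%.
Compound 2 `CCC(C(=O)N1CCN(c2ccccc2C(F)(F)F)CC1)N1C(=O)CCC1=O` gives 0%.
Compound 3 `CC(C(=O)N1CCOCC1)N1C(=O)CCC1=O` gives 0%.

Compound 1 and compound 2 share a core and differ only by methyl in place of hydrogen on a saturated chain carbon, two bonds along the chain from an amide-type nitrogen in a ring and a carbonyl carbon; in this assay this change made a number 75 percentage points lower from compound 1 to compound 2 (beyond the scatter). Compound 3 has a different core; how the core of compound 3 differs from the core of compound 1 is not broken down here. Compound 3 and compound 2 show the same value.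

Compound 4 `CCC(C(=O)N1CCOCC1)N1C(=O)CCC1=O` is not yet measured. It differs from compound 3 by methyl in place of hydrogen on a saturated chain carbon, two bonds along the chain from an amide-type nitrogen in a ring and a carbonyl carbon, the same change as that from compound 1 to compound 2. Because compound 3 already gives 0%, there is no room for a fall of that size, and compound 4 is expected to show about no change at the digits printed from compound 3 to compound 4 (within the scatter). The estimate for compound 4 in this assay is 0%, expected to lie between 0% and 10%.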

Compound 4, a percentage reported as activity, at one dose (the size of the read-out at that dose, not a potency): 0%
Compound 4: middle estimate and measured number agree at the digits printed; the range from low to high includes it.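

In this assay, putting methyl in place of hydrogen on the core of compound 3 gave no change at the digits printed from compound 3 to compound 4 (within the scatter). Set beside the earlier step, the same change did not give the same result on the two cores: the same change on two cores in this assay, a number 75 percentage points lower (beyond the scatter) from compound 1 to compound 2 and no change at the digits printed (within the scatter) from compound 3 to compound 4, 75 percentage points apart, beyond the scatter of two such steps

This does not show that the core of compound 3 tolerates the change better: compound 3 already gives 0%, which leaves no room for a fall, so only the core of compound 1 can reveal a loss. The compounds shown leave open how a longer chain, such as propyl, or a hydroxyl group on that saturated chain carbon would behave on the core of compound 1. They also leave open whether any group there keeps the effect seen with hydrogen.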